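Swapping trifluoromethyl for chloro on a trimethoxy chalcone core

This account rests on a few compounds, and the source may have more. Where it says the series, first, only, none or still open, it means among the compounds named here.

Measured compounds:
compound 1 `COc1cc(O)cc(O)c1C(=O)/C=C/c1ccc(Cl)cc1` gives 17000 nM
compound 2 `COc1cc(O)cc(O)c1C(=O)/C=C/c1ccc(C(F)(F)F)cc1` gives 9500 nM
compound 3 `COc1cc(OC)c(C(=O)/C=C/c2ccc(C(F)(F)F)cc2)c(OC)c1` gives 5100 nM

These values come from a functional assay on HeLa cells (Homo sapiens) for inhibition, read by MTT assay, with a stated time of 72 h; a lower number here means a stronger inhibitor, a higher number a weaker inhibitor. Compound 1 differs from compound 2 by chloro in place of trifluoromethyl on an aromatic carbon and the step from compound 2 to compound 1 is a 1.8-fold higher number from compound 2 to compound 1 (0.25 log units; within the scatter). The difference between the core of compound 2 and the core of compound 3 is not broken down here. Compound 4 `COc1cc(OC)c(C(=O)/C=C/c2ccc(Cl)cc2)c(OC)c1` is not yet measured; it differs from compound 3 by chloro in place of trifluoromethyl on an aromatic carbon, the same change that leads from compound 2 to compound 1. The step from compound 3 to compound 4 is therefore expected to resemble it, namely a 1.8-fold higher number from compound 3 to compound 4 (0.25 log units; within the scatter), because the earlier step was a 1.8-fold higher number from compound 2 to compound 1 (0.25 log units; within the scatter). Compound 4 is estimated at 9000 nM, between 4000 nM and 22000 nM.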

Compound 4, half-maximal inhibitory concentration: 3900 nM
Beside the measured number, compound 4's estimate is 2.3-fold (0.36 log units) above it; measured number below the stated range.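

In this assay, the new swap of chloro for trifluoromethyl is a 1.3-fold lower number from compound 3 to compound 4 (0.12 log units; within the scatter), so this step is too small to tell apart from repeat-measurement noise. The two steps point in opposite directions on paper, but the gap between them is no larger than repeated measurements can produce: the same change on two cores in this assay, a 1.8-fold higher number (0.25 log units; within the scatter) from compound 2 to compound 1 and a 1.3-fold lower number (0.12 log units; within the scatter) from compound 3 to compound 4, 2.3-fold (0.37 log units) apart, within the scatter of two such steps. This fits the change carrying from one core to the other as a small step, but two pairs in one assay cannot give the change a direction or show that it would carry to a further core.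

Still open, as far as these compounds go, is whether an amine, a carboxylic acid or a nitrile in place of chloro would give a step beyond the scatter. Also open, from the compounds shown here alone, is how this swap behaves on cores other than these two.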